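Thiazole for Methylsulfanyl in a Piperidine Carboxamide Series

The source may hold more compounds than are shown below. What is called first, only, known or untested is meant among the compounds shown, and "the series" means these compounds.

Of the compounds shown here, three of a shared piperidine carboxamide core have been measured in an ADME assay on PC-3 cells (Homo sapiens) for cytotoxicity, read by WST assay, tested at 100 uM; a higher number here means more inhibition at the concentration tested (going by the name of the read-out), a lower number less inhibition. Compound 1 `CSc1cccc(NC(=O)C2CCCN(C(=O)c3cc(C(F)(F)F)cc(C(F)(F)F)c3)C2)c1` gives 0% in this assay. Compound 2 `CC(=O)Nc1cccc(C(=O)N2CCCC(C(=O)Nc3ccc(Cl)cc3)C2)c1` gives 4% in this assay, and compound 3 `O=C(Nc1cccc(Cc2ccccc2)c1)C1CCCN(C(=O)c2cccc(-c3ccco3)c2)C1` gives 0% in this assay. Compound 1 stands level with compound 3 at the digits reported, and the number for compound 2 sits within the usual scatter of both, so no ordering among the three can be read from these values.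

The next compound follows from compound 1 by a single change. Compound 4 `Cc1nc(-c2cccc(NC(=O)C3CCCN(C(=O)c4cc(C(F)(F)F)cc(C(F)(F)F)c4)C3)c2)cs1` carries 2-methyl-1,3-thiazol-4-yl in place of methylsulfanyl on an aromatic carbon. The place of the change is an aromatic carbon of a six-membered aromatic ring of carbon only, meta to a large group; the same difference, cut one bond further out, reads 3-(methylsulfanyl)phenyl to 3-(2-methyl-1,3-thiazol-4-yl)phenyl.

For the measured compounds named here, no pair of measured compounds differing in one place is available to calibrate this change, and the three measured values all fall within the scatter of one another. The step is therefore expected to be a number 3 percentage points higher from compound 1 to compound 4 (within the scatter), that is, none beyond the scatter in either direction. Compound 4 is estimated at 3% in this assay, with a range of -8% to 16%.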

Compound 4, a percentage reported as inhibition, at one concentration (the size of the read-out at that concentration, not a potency): 1%
Beside the measured number, compound 4's estimate is 2 percentage points above it, within the range that was stated.
By their numbers in this assay, from the lowest: compounds 1, 3, 4 and 2 (each within the scatter of the next).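

The step gives this series its first comparison between compounds that differ in one place: in this assay, the read-out moves by a number 1 percentage points higher from compound 1 to compound 4 (within the scatter) when 2-methyl-1,3-thiazol-4-yl takes the place of methylsulfanyl. At this aromatic carbon, meta to a large group, a group with no ring and one carrying a five-membered aromatic ring therefore cannot be told apart in this read-out, although the entering group has more heavy atoms and an added ring nitrogen. No measurement on these compounds bears on why the two groups read alike, so the result stands without an explanation.

Both compounds lie close to the bottom of the read-out, so the comparison says little about whether a group of a different kind at this position, such as a primary amine or a carboxylic acid, would move the number beyond the scatter. On these data alone, it also remains open whether the same exchange would read alike on a version of the core without the two trifluoromethyl groups, for example one carrying the acetamide-bearing benzoyl group of compound 2.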